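Ring size of the amine ring and buffer solubility

The source may hold more compounds than are shown below. What is called first, only, known or untested is meant among the compounds shown, and "the series" means these compounds.

Compound 1 `CC(=O)Nc1cc(Nc2cc(NC3CC3)n3ncc(C#N)c3n2)ccc1N1CCC[C@@H](N)C1`: > 1000000 nM
Compound 2 `CC(=O)Nc1cc(Nc2cc(NC3CC3)n3ncc(C#N)c3n2)ccc1N1CC[C@H](N)C1`: 590000 nM

For the measured compounds named here, in a physicochemical assay for solubility, read by LC-MS, in phosphate buffer, with a stated time of 24 h, at pH 7.4 (on this read-out lower numbers stand for lower solubility and higher numbers for higher solubility), compound 2 gives 590000 nM, the only plain number among the two values shown. For compound 1 the read-out is a limit of the assay, > 1000000 nM, which is the limit of > 1000000 nM in this assay, at which 1 of the 2 values shown sits. Compound 3 `CC(=O)Nc1cc(Nc2cc(NC3CC3)n3ncc(C#N)c3n2)ccc1N1CCC[C@H](N)C1` differs from compound 2 as follows: 3-aminopiperidin-1-yl in place of 3-aminopyrrolidin-1-yl on an aromatic carbon. Going by the values given here, the one measured step, an at least 1.6-fold lower number from compound 1 to compound 2 (0.22 log units; that floor lies within the scatter), runs through the same exchange in the opposite direction and lies within the scatter at its floor, so the ring change carries no clear effect of its own here; compound 3 differs from compound 1 only at the defined stereocentre. Compound 3 is therefore expected to sit near or at the same limit as compound 1. The step expected is a 1.7-fold higher number from compound 2 to compound 3 (0.23 log units; within the scatter). The estimate for compound 3 is 1000000 nM, with a range from 450000 nM to 2500000 nM, and a report of a limit rather than a number is likely.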

Compound 3, solubility: 704000 nM
For compound 3 the middle estimate is 1.4-fold (0.15 log units) above the measured one; low and high end bracket the measured number.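

In this assay, the exchange of 3-aminopyrrolidin-1-yl for 3-aminopiperidin-1-yl on the aromatic carbon can now be read between two plain numbers: a 1.2-fold higher number from compound 2 to compound 3 (0.08 log units; within the scatter). At this position, ring size therefore shows no effect beyond the scatter in this pair, which has the S configuration as drawn in compound 3. The other new step, an at least 1.4-fold lower number from compound 1 to compound 3 (0.15 log units; that floor lies within the scatter), gives only a floor for the change of configuration, and that floor shows no effect beyond the scatter: the fact that compounds 1 and 3 differ only in the configuration as drawn.

From the compounds shown here alone, the real distance between the R and S forms remains open, as the value of compound 1 is a limit: the limit of > 1000000 nM in this assay, at which 1 of the 3 values shown sits. Also open, going by these compounds, is how the read-out responds when morpholin-4-yl or a piperidine bearing a carboxylic acid stands at this position.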